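Swapping the difluorophenol group on compound 2

The compounds below may be only part of what the source reports. "The series", "measured", "known", "first", "only" and "open" are said of these compounds alone.

Measured so far in a functional assay on MCF7 cells (Homo sapiens) for inhibition, read by resazurin assay, with a stated time of 24 h; a lower number here means a stronger inhibitor, a higher number a weaker inhibitor:
compound 1 `O=C1Nc2c(C(F)(F)F)cccc2C1(c1ccc(OC(F)(F)F)cc1)c1ccc(O)c(F)c1` gives 33 nM
compound 2 `O=C1Nc2c(C(F)(F)F)cccc2C1(c1ccc(OC(F)(F)F)cc1)c1c(F)cc(O)cc1F` gives 549 nM
compound 3 `O=C1Nc2c(C(F)(F)F)cccc2[C@]1(c1ccc(OC(F)(F)F)cc1)c1ccc(O)c(O)c1` gives 24 nM

A lower number marks a stronger inhibitor, so compound 2, with the highest of the three numbers, is the weakest. The values of compound 1 and compound 3 lie within the usual scatter of each other, and both lie far under that of compound 2.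

The next compound to be tested, compound 4 `Cc1cc(C2(c3ccc(OC(F)(F)F)cc3)C(=O)Nc3c(C(F)(F)F)cccc32)ccc1O`, replaces one group of compound 2: 4-hydroxy-3-methylphenyl in place of 2,6-difluoro-4-hydroxyphenyl on a saturated ring carbon. In words, 4-hydroxy-3-methylphenyl stands in place of 2,6-difluoro-4-hydroxyphenyl on a saturated ring carbon.

Within the data shown here, one measured step bears directly on this change. Moving the other way, a 17-fold higher number from compound 1 to compound 2 (1.22 log units; beyond the scatter) was large, and it brought in the same 2,6-difluoro-4-hydroxyphenyl group that compound 4 gives up. Compound 4 instead resembles compound 1, which carries 3-fluoro-4-hydroxyphenyl at this place. Among the measured compounds shown here, no measured compound carries the methyl group itself, so the range must stay wide.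

A large drop in this assay is expected, with an estimated change of a 14-fold lower number from compound 2 to compound 4 (1.14 log units; beyond the scatter). For compound 4 the estimated value is 40 nM, with an expected range from 14 nM to 120 nM.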

Compound 4, half-maximal inhibitory concentration: > 1000 nM
Compound 4 ended at the assay's limit; the forecaster's own chance of this, stated with the estimate: 2%; middle value at least 25-fold (1.39 log units) from the limit.
By their numbers in this assay, from the lowest: compounds 3 and 1 (each within the scatter of the next); then compound 2. At a limit, above all of these: compound 4.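

Compound 4 sits at a limit of this assay, which is not a number: the limit of > 1000 nM in this assay, at which 1 of the 4 values shown sits.

Methyl in place of fluoro on an aromatic carbon gives an at least 30-fold higher number from compound 1 to compound 4 (1.48 log units; beyond the scatter), so the low number of compound 1 does not carry over from fluoro to methyl, and a single replacement on this ring separates a strong inhibitor from one at the limit. The other step reads an at least 1.8-fold higher number from compound 2 to compound 4 (0.26 log units; that floor lies within the scatter). This floor does not show that 4-hydroxy-3-methylphenyl is worse than 2,6-difluoro-4-hydroxyphenyl on the saturated ring carbon, only that it does not bring back the low number of compound 1.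

How far the true value of compound 4 lies past the limit stays unknown, and the compounds shown give no reason for the loss. Also open, from the compounds shown here alone, is whether a chlorine, a methoxy group or an amine in place of the methyl of compound 4 would follow the fluoro of compound 1 or the methyl of compound 4.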